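Sulfonyl aryl swap in a piperazine sulfonamide series

This account rests on a few compounds, and the source may have more. Where it says the series, first, only, none or still open, it means among the compounds named here.

Compound 1 `O=C(NCc1ccc(F)cc1)c1ccc(N2CCN(S(=O)(=O)c3cccnc3C3CC3)CC2)nn1` is the starting point. Going by the values given here, in an ADME assay on microsomes from liver (Mus musculus) for metabolic stability, read by LC-MS, using NADPH, tested at 10 uM (a higher number here means that the compound lasts longer, a lower number that the compound disappears faster), compound 1 gives 0.1 h, the lowest of the two numbers known here; compound 2 `N#Cc1ncccc1S(=O)(=O)N1CCN(c2ccc(C(=O)NCc3ccc(F)cc3)[n+]([O-])n2)CC1` gives 0.267 h, a gap beyond the scatter. Compound 3 `O=C(NCc1ccc(F)cc1)c1ccc(N2CCN(S(=O)(=O)c3ccccc3C(F)(F)F)CC2)nn1` differs from compound 1 only at the sulfonyl sulfur: 2-(trifluoromethyl)phenyl in place of 2-cyclopropylpyridin-3-yl on a sulfonyl sulfur. Among the compounds with values here, no measured pair shows this kind of change, so its effect can only be guessed. A small step of a 1.5-fold higher number from compound 1 to compound 3 (0.18 log units; within the scatter) is expected, if anything upward, and likely within the scatter. Compound 3 is therefore estimated at 0.15 h, with a range from 0.05 h to 0.45 h.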

Compound 3, half-life: 0.517 h
Compound 3: middle estimate off by 3.4-fold (0.54 log units), on the low side; measured number outside the range, above it.
By their numbers in this assay, from the lowest: compound 1; then compounds 2 and 3 (each within the scatter of the next).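

In this assay the group on the sulfonyl sulfur proves able to move the half-life on its own: 2-(trifluoromethyl)phenyl in place of 2-cyclopropylpyridin-3-yl gives a 5.2-fold higher number from compound 1 to compound 3 (0.71 log units; beyond the scatter) with the rest of compound 1 unchanged. Going by these compounds alone, this is the first single-place step, and it lies beyond the scatter. No measurement at hand accounts for the step.

The change replaces ring and substituent together, so their shares remain unseparated. A 2-cyclopropylphenyl or a 2-(trifluoromethyl)pyridin-3-yl group on the same sulfonyl sulfur would divide them.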